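The source may hold more compounds than are shown below. What is called first, only, known or untested is meant among the compounds shown, and "the series" means these compounds.

Compound 3 `COc1ccc2c(=O)c(-c3cc(OC)c(OC)cc3OC)coc2c1` carries a methoxy on the shared core and, in a functional assay on B16 cells (Mus musculus) for antiproliferative activity, read by MTT assay, with a stated time of 24 h (a lower number here means a stronger inhibitor, a higher number a weaker inhibitor), compound 3 gives 5200 nM, the highest of the three numbers measured. Compound 1 `C#CCOc1ccc2c(=O)c(-c3cc(OC)c(OC)cc3OC)coc2c1` gives 4500 nM and compound 2 `COc1cc(OC)c(-c2coc3cc(OCc4ccccc4)ccc3c2=O)cc1OC` gives 2330 nM. The change to compound 4 `COc1cc(OC)c(-c2coc3cc(OCc4ccc(F)cc4)ccc3c2=O)cc1OC` is 4-fluorophenyl in place of hydrogen on a saturated chain carbon bound to an oxygen on an aromatic ring. The step that bears on it most closely runs the other way: a 2.2-fold higher number from compound 2 to compound 3 (0.35 log units; beyond the scatter), a modest but real loss on going to hydrogen. The other two steps, a 1.9-fold lower number from compound 1 to compound 2 (0.29 log units; within the scatter) and a 1.2-fold higher number from compound 1 to compound 3 (0.06 log units; within the scatter), stay within the scatter. Adding a 4-fluorophenyl is therefore expected to roughly retrace the phenyl step, giving a modest lower number, a 2.2-fold lower number from compound 3 to compound 4 (0.34 log units; beyond the scatter). Compound 4 is estimated at 2400 nM, with a range of 1100 nM to 5200 nM.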

Compound 4, half-maximal inhibitory concentration: 1120 nM
The estimate for compound 4 lay 2.1-fold (0.33 log units) above the measured number; the range from low to high includes it.
By their numbers in this assay, from the lowest: compound 4; then compounds 2, 1 and 3 (each within the scatter of the next, the first and the last beyond it).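

In this assay, 4-fluorophenyl on the saturated chain carbon is the first change at this position to set a compound apart, beyond the scatter, from every other compound shown: a 4.6-fold lower number from compound 3 to compound 4 (0.67 log units; beyond the scatter) and a 4.0-fold lower number from compound 1 to compound 4 (0.60 log units; beyond the scatter). The fluoro itself also counts, since fluoro in place of hydrogen on an aromatic carbon gives a 2.1-fold lower number from compound 2 to compound 4 (0.32 log units; beyond the scatter). No measurement at hand accounts for either step. From the compounds shown here alone, whether chloro or methoxy in place of the fluoro would give the same result remains open. So does the outcome with an amine or a carboxylic acid on the phenyl ring.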